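A few compounds are considered here, and "the series" means these few. Any claim that something is new, unique, unknown or untested is made for them only; others in the source may bear on it.

In a functional assay on NCI-H460 cells (Homo sapiens) for cytotoxicity, read by MTT assay, with a stated time of 48 h; a higher number here means a weaker inhibitor, a lower number a stronger inhibitor:
- Compound 1 `COc1cc(OC)c(OC)cc1/C=C/C(=O)/C=C/c1cc2ccccc2nc1Cl`: 3960 nM
- Compound 2 `COc1ccc(OC)c(/C=C/C(=O)/C=C/c2cc3ccccc3nc2Oc2cccc(Cl)c2)c1`: > 10000 nM (a limit)
- Compound 3 `COc1ccc(/C=C/C(=O)/C=C/c2cc3ccccc3nc2Oc2cccc(Cl)c2)cc1OC`: > 10000 nM (a limit)

Compound 3 stands at > 10000 nM, which is a limit and not a number. Compound 4 `COc1cc(OC)c(OC)cc1/C=C/C(=O)/C=C/c1cc2ccccc2nc1Oc1cccc(Cl)c1` differs from it by one change, methoxy in place of hydrogen on an aromatic carbon, which turns 3,4-dimethoxyphenyl into 2,4,5-trimethoxyphenyl.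

Little of what has been measured gives a size for this change. The overall picture is the limit of > 10000 nM in this assay, at which 2 of the 3 values shown sit. Among the compounds with values here, the only measured step is a step that the two limits leave unreadable from compound 2 to compound 3, and it offers no size to carry over. Compound 1, which also carries the 2,4,5-trimethoxyphenyl group but differs elsewhere, gives 3960 nM. A readable number in this assay is therefore possible, and any shift is expected towards a stronger inhibitor, although a result at the limit remains the likelier outcome. The estimated change is a number no higher from compound 3 to compound 4 (the limit leaves the size open). For compound 4 the expected value is 10000 nM, with an estimated range from 3000 nM to 20000 nM.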

Compound 4, half-maximal inhibitory concentration: > 10000 nM
Compound 4: only a limit was reported (the forecaster's own chance of this, stated with the estimate: 60%); the middle value sits exactly at the limit.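

Adding a methoxy group, which turns 3,4-dimethoxyphenyl into 2,4,5-trimethoxyphenyl, does not lift compound 4 to a readable number in this assay: compound 4 gives > 10000 nM, which is a limit. Within the data shown here, the steps linking compound 2, compound 3 and compound 4 cannot be read, so this methoxy change still has no size, and the overall picture stays as it was: the limit of > 10000 nM in this assay, at which 3 of the 4 values shown sit. The 2,4,5-trimethoxyphenyl group alone therefore does not ensure a readable value, and the one step that can be read is an at least 2.5-fold higher number from compound 1 to compound 4 (0.40 log units; beyond the scatter), with 3-chlorophenoxy in place of chloro on an aromatic carbon.

Still open, as far as these compounds go, is how far beyond the limit compound 3 and compound 4 lie, and whether they differ at all. Also open, from the compounds shown here alone, is what an amine in place of chloro would give alongside the 2,4,5-trimethoxyphenyl group.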